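Allyl-substituted diketopiperazine analogs: methoxy for chloro

A few compounds are considered here, and "the series" means these few. Any claim that something is new, unique, unknown or untested is made for them only; others in the source may bear on it.

Measured:
compound 1 `COc1ccccc1/C=c1/[nH]c(=O)/c(=C\c2cccc(Cl)c2Cl)[nH]c1=O` — "not active" (no number reported)
compound 2 `C=CCn1c(=O)/c(=C\c2ccccc2Cl)[nH]c(=O)/c1=C\c1ccccc1OC` — 2500 nM

In a functional assay on K562 cells (Homo sapiens) for cytotoxicity, read by CCK-8 assay, with a stated time of 72 h (on this read-out lower numbers stand for stronger inhibition and higher numbers for weaker inhibition), compound 2 gives 2500 nM. Going by the values given here, this is the only numerical value; compound 1 is reported without a number, so compound 2 cannot be ranked against it, and no step between measured compounds is available.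

Compound 3 `C=CCn1c(=O)/c(=C\c2ccccc2OC)[nH]c(=O)/c1=C\c1ccccc1OC` is not yet measured. It differs from compound 2 in one place: methoxy in place of chloro on an aromatic carbon. The change makes both aryl groups on the shared core the same. Among the compounds with values here, with only one number in hand, the size of the step cannot be read from the series; a chloro-to-methoxy exchange of this kind is expected to move this assay by a modest amount, most likely toward weaker inhibition, though a result within the scatter is also possible. Within the data shown here, a reference point is that compound 1, which carries the same 2-methoxyphenyl group, is reported as "not active" (no number reported), but it also differs elsewhere and gives no step.

For compound 3 the estimate in this assay is 5000 nM (range 1500 nM to 20000 nM), corresponding to an expected step of a 2.0-fold higher number from compound 2 to compound 3 (0.30 log units; within the scatter).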

Compound 3, half-maximal inhibitory concentration: 7400 nM
Estimate against measurement, compound 3: 1.5-fold (0.17 log units) below; the range from low to high includes it.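

In this assay, the series now has its first readable step: exchanging 2-chlorophenyl for 2-methoxyphenyl, with methoxy in place of chloro on an aromatic carbon, gives a 3.0-fold higher number from compound 2 to compound 3 (0.47 log units; beyond the scatter). This position therefore responds to the exchange, and in this single pair the chloro compound carries the lower number, by a margin beyond the usual scatter of the read-out. The exchange does not remove measurable activity, as compound 3, with the same aryl group on both sides of the shared core, still gives 7400 nM, but no measurement of any property of the two groups accompanies the step, so its direction remains an observation without an explanation.

On these data alone, it remains open whether the step reflects the arrival of methoxy or the departure of chloro, and how an amine, a hydroxyl or a longer ethoxy chain at this aromatic carbon would read in this assay. The contribution of the allyl group and any step involving compound 1 cannot be read: compound 1 has no number and differs from the other two compounds in more than one place.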